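Widening a Ring on the Urea Nitrogen

The compounds below may be only part of what the source reports. "The series", "measured", "known", "first", "only" and "open" are said of these compounds alone.

Of the compounds shown here, two sharing one core have been measured in a functional assay on the whole organism for inhibition, with Rattus norvegicus as the target, at a dose of 30 mg/kg by the oral route; a higher number here means more inhibition at the dose given (going by the name of the read-out), a lower number less inhibition. Compound 1 `CN(C(=O)NCCCOc1ccc2nc(O)ccc2c1)[C@@H]1CCCC[C@H]1O` gives 10%. Compound 2 `O=C(NCCCOc1ccc2nc(O)ccc2c1)N(C1CCCC1)[C@H]1CCCC[C@@H]1O` gives 20%, a number that lies within the usual scatter of the value for compound 1, so the two stand together rather than apart. Compound 3 `O=C(NCCCOc1ccc2nc(O)ccc2c1)N(C1CCCCCC1)[C@H]1CCCC[C@@H]1O` has not yet been measured and differs from compound 2 in one place: cycloheptyl in place of cyclopentyl on an amide-type nitrogen. Going by the values given here, no step between measured compounds is available to guide the expectation. The step of a number 5 percentage points higher from compound 2 to compound 3 (within the scatter) is expected to be small, not clearly beyond the scatter. Compound 3 is estimated to give 25%, with a range from 5% to 50%.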

Compound 3, a percentage reported as inhibition, in the whole organism at one dose (the size of the read-out at that dose, not a potency): 11%
The estimate for compound 3 lay 14 percentage points above the measured number; the range from low to high includes it.
By their numbers in this assay, from the lowest: compounds 1, 3 and 2 (each within the scatter of the next).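

In this assay, cycloheptyl in place of cyclopentyl on the amide-type nitrogen gives a number 9 percentage points lower from compound 2 to compound 3 (within the scatter) and so does not clearly move the read-out. Going by these compounds alone, this is the first single-place comparison at this nitrogen, and adding ring size here brings no clear gain or loss at this dose. No supporting measurement is available to explain this result.

Still open, from the compounds shown here alone, is whether a group of another kind at this nitrogen, such as a piperidine ring or an open chain carrying a carboxylic acid, moves the number beyond the scatter.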